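The source may hold more compounds than are shown below. What is called first, only, known or untested is meant among the compounds shown, and "the series" means these compounds.

Compound 1 `COc1ccc(/C=C\c2cc(OC)c(OC)c(OC)c2)cc1OCc1ccc(CN2CC[C@H](C(=O)O)C2)cc1`: 7000 nM
Compound 2 `COc1ccc(/C=C\c2cc(OC)c(OC)c(OC)c2)cc1OCc1ccc(CN2CCCC[C@H]2C(=O)O)cc1`: > 10000 nM
Compound 3 `COc1ccc(/C=C\c2cc(OC)c(OC)c(OC)c2)cc1OCc1ccc(CN2CC[C@@H](C(=O)O)C2)cc1`: > 10000 nM

All three share one core and differ only in the group sitting on a saturated chain carbon bound to an aromatic carbon. Going by the values given here, in a functional assay on B16-F10 cells (Mus musculus) for antiproliferative activity, read by CCK-8 assay, with a stated time of 48 h (a higher number here means a weaker inhibitor, a lower number a stronger inhibitor), compound 1 gives 7000 nM, the only number among the three values. Compound 2 gives > 10000 nM, which is a limit of the assay and not a number. Compound 3 gives > 10000 nM, again a limit rather than a number. The step of an at least 1.4-fold higher number from compound 1 to compound 2 (0.15 log units; that floor lies within the scatter) and the step of an at least 1.4-fold higher number from compound 1 to compound 3 (0.15 log units; that floor lies within the scatter) therefore both run upward, and because of the limit of > 10000 nM in this assay, at which 2 of the 3 values shown sit, only their floors can be read, floors that lie within the scatter. Because of the fact that compounds 1 and 3 differ only in the configuration as drawn, the step to compound 3 shows that even a change of drawn configuration alone moved the value to the limit.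

Compound 4 `COc1ccc(/C=C\c2cc(OC)c(OC)c(OC)c2)cc1OCc1ccc(CNC(C)(C)C(=O)O)cc1` carries a further change at the same place: (1-carboxy-1-methylethyl)amino in place of 3-carboxypyrrolidin-1-yl on a saturated chain carbon bound to an aromatic carbon. Both changes made so far to the 3-carboxypyrrolidin-1-yl of compound 1 ended at the limit, so compound 4 is expected to take an upward step, a 1.7-fold higher number from compound 1 to compound 4 (0.23 log units; within the scatter). Compound 4 is estimated at 12000 nM, within 5000 nM to 30000 nM, and a reading that is only a limit is thought likely.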

Compound 4, half-maximal inhibitory concentration: > 10000 nM
Compound 4 ended at the assay's limit (the forecaster's own chance of this, stated with the estimate: 60%); the middle value lies beyond the limit too.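

The new group, (1-carboxy-1-methylethyl)amino, has no ring and no defined stereocentre, so on this saturated chain carbon the limit is now reached by a group without a ring as well as by the ring-bearing groups of compounds 2 and 3. In this assay the change reads as an at least 1.4-fold higher number from compound 1 to compound 4 (0.15 log units; that floor lies within the scatter), so no real loss of activity can be claimed for it, and opening the ring cannot be said to have harmed or spared activity. That step can be read only as a floor, and the steps among compounds 2, 3 and 4 cannot be read at all, because of one shared feature of these values: the limit of > 10000 nM in this assay, at which 3 of the 4 values shown sit.

On these data alone, all four compounds carry a carboxylic acid in this group, so what happens when it is absent remains open, for example with a plain pyrrolidin-1-yl or with the methyl ester of the acid. Also open, as far as these compounds go, is how far compounds 2, 3 and 4 lie from one another, and from compound 1, beyond the limit.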